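Replacing Quinolin-2-yl with Pyridin-4-yl: an Expected Outcome

This account rests on a few compounds, and the source may have more. Where it says the series, first, only, none or still open, it means among the compounds named here.

Compound 1 `O=C1OC(c2cnc3ccccc3c2)CN1C1CCN(Cc2cc3ccccc3[nH]2)CC1` — < 50200 nM
Compound 2 `O=C1OC(c2ccc3ccccc3n2)CN1C1CCN(Cc2cc3ccccc3[nH]2)CC1` — < 50200 nM

In an in vitro functional assay on RBL cells for antagonist activity at C-C chemokine receptor type 8 (Homo sapiens), read by FLIPR and calcium flux (on this read-out lower numbers stand for stronger inhibition and higher numbers for weaker inhibition), compound 1 gives only a limit, < 50200 nM. Compound 2 likewise gives only a limit in this assay, < 50200 nM. The step that the two limits leave unreadable from compound 1 to compound 2 is thus not readable, as both values sit at the limit of < 50200 nM in this assay, at which 2 of the 2 values shown sit. Compound 3 `O=C1OC(c2ccncc2)CN1C1CCN(Cc2cc3ccccc3[nH]2)CC1` differs from compound 2 by pyridin-4-yl in place of quinolin-2-yl on a saturated ring carbon. Among the compounds with values here, no measured step bears on this change with a readable size, so the step that the limit leaves unreadable from compound 2 to compound 3 is expected to be small and may in either direction stay within the scatter. Compound 3 is therefore estimated at 8000 nM, within a range from 800 nM to 50000 nM, with a real chance that only a limit is reported.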

Compound 3, half-maximal inhibitory concentration: < 50200 nM
Compound 3 was reported as a limit; the forecaster's own chance of this, stated with the estimate: 55%; the middle value lies beyond the limit too.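

Compound 3, like compound 1 and compound 2, gives only a limit in this assay, so none of the steps among these compounds can be read: the limit of < 50200 nM in this assay, at which 3 of the 3 values shown sit.

The compounds shown leave open whether quinolin-3-yl, quinolin-2-yl and pyridin-4-yl differ at all in this assay.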